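Iodination of the dihydropyranone core: expected effect on growth inhibition

A few compounds are considered here, and "the series" means these few. Any claim that something is new, unique, unknown or untested is made for them only; others in the source may bear on it.

Measured so far:
compound 1 `COc1ccc(C2CC(=O)C=CO2)cc1` — 249 uM
compound 2 `COc1ccc(-c2cc(=O)cco2)cc1` — > 1230 uM

For the measured compounds named here, in a functional assay on OVCAR-3 cells (Homo sapiens) for inhibition, read by sulforhodamine B assay, with a stated time of 48 h (a lower number here means a stronger inhibitor of growth, a higher number a weaker inhibitor of growth), compound 1 gives 249 uM, the only numerical value. For compound 2 only a limit is reported, (the limit of > 1230 uM in this assay, at which 1 of the 2 values shown sits). Compound 3 `COc1ccc(C2CC(=O)C(I)=CO2)cc1` differs from compound 1 by iodo in place of hydrogen on a double-bonded ring carbon. Going by the values given here, no measured pair shows a comparable change, so no measured step guides the size of the shift. Compound 3 is expected to be a somewhat stronger growth inhibitor than compound 1, with a step of a 3.1-fold lower number from compound 1 to compound 3 (0.49 log units; beyond the scatter). The estimate for compound 3 is 80 uM, in a range from 20 uM to 300 uM.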

Compound 3, concentration for growth inhibition (reported as GI): 38.2 uM
For compound 3 the middle estimate is 2.1-fold (0.32 log units) above the measured one, within the range that was stated.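

In this assay iodo in place of hydrogen gives a 6.5-fold lower number from compound 1 to compound 3 (0.81 log units; beyond the scatter) on a double-bonded ring carbon two ring bonds from the ring oxygen. For the compounds shown here, this is the first measured step, and it shows that this position responds to substitution, with a single heavy atom enough to move growth inhibition. Nothing at hand gives a cause for the step.

On these data alone, how chloro, a methyl group or an amine on this carbon would compare with iodo stays open. As far as these compounds go, whether the step carries over to other cell lines also stays open.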